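A few compounds are considered here, and "the series" means these few. Any claim that something is new, unique, unknown or untested is made for them only; others in the source may bear on it.

Compound 2 `COc1ccc2c(O[C@H]3C[C@H]4C(=O)N(C)CCCC/C=C/[C@@H]5C[C@@]5(C(=O)NS(=O)(=O)C5(C)CC5)NC(=O)N4C3)cc(-c3nc(C(C)C)cs3)nc2c1` was tested in an ADME assay on Huh-7 cells (Homo sapiens) for cytotoxicity, read by colorimetric assay (on this read-out lower numbers stand for higher toxicity in this test and higher numbers for lower toxicity in this test), where compound 2 gives 42700 nM. Its one companion, compound 1 `COc1ccc2c(O[C@H]3C[C@H]4C(=O)N(C)CCCC/C=C/[C@@H]5C[C@@]5(C(=O)NS(=O)(=O)C5(C)CC5)NC(=O)N4C3)cc(-c3nc(C(F)(F)F)cs3)nc2c1C`, gives 75000 nM in this assay. These two numbers lie within the usual scatter of each other, so on this test compound 2 and compound 1 cannot be told apart, and compound 2 stands simply alongside compound 1 rather than apart from it.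

Compound 3 `COc1ccc2c(O[C@H]3C[C@H]4C(=O)N(C)CCCC/C=C/[C@@H]5C[C@@]5(C(=O)NS(=O)(=O)C5(C)CC5)NC(=O)N4C3)cc(-c3nc(C(C)C)cs3)nc2c1Cl` has not yet been measured. It differs from compound 2 in a single place: chloro in place of hydrogen on an aromatic carbon. Within the data shown here, no pair of compounds already measured shows what such a change does on this read-out, so there is no measured step to lean on. The expectation is therefore that compound 3 stays close to compound 2, with the step in this assay estimated at a 1.0-fold lower number from compound 2 to compound 3 (0.01 log units; within the scatter), that is, no movement beyond the usual scatter in either direction. On that basis compound 3 is expected to give about 42000 nM in this assay, within a range running from 15000 nM to 110000 nM.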

Compound 3, half-maximal cytotoxic concentration: 48500 nM
Compound 3: middle estimate off by 1.2-fold (0.06 log units), on the low side, within the range that was stated.
By their numbers in this assay, from the lowest: compounds 2, 3 and 1 (each within the scatter of the next).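

In this assay, placing chloro in place of hydrogen on this aromatic carbon, ortho to a methoxy group and ortho to a fused ring, gives a 1.1-fold higher number from compound 2 to compound 3 (0.06 log units; within the scatter) and so provides a measured step at this position. Within the usual scatter of the test, the added chlorine atom therefore makes no detectable difference between the two compounds, so hydrogen and chloro cannot be told apart here on this read-out. Nothing measured alongside this result offers an explanation for it.

This single pair covers only one substitution, on one version of the shared core, so it cannot show whether a group of a different kind at this carbon, such as an amine, a carboxylic acid or a longer chain such as propyl, would also leave the read-out unmoved. It also leaves open whether chloro would behave the same way on another carbon of this six-membered aromatic ring, or with a group other than the isopropyl on the five-membered ring of compound 2.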